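Swapping Dimethylamino for Fluoro on a Growth Inhibitor

A few compounds are considered here, and "the series" means these few. Any claim that something is new, unique, unknown or untested is made for them only; others in the source may bear on it.

Measured so far in a functional assay on A2780 cells (Homo sapiens) for inhibition, read by sulforhodamine B assay; a lower number here means a stronger inhibitor of growth, a higher number a weaker inhibitor of growth:
- Compound 1 `Cc1ccc2[nH]c(-c3ccc(-c4ccc(-c5ccc(N(C)C)cc5)cc4)cc3)nc2c1`: 2210 nM
- Compound 2 `CN(C)c1ccc(-c2ccc(-c3ccc(-c4nc5c(O)cccc5[nH]4)cc3)cc2)cc1`: 3010 nM

For the measured compounds named here, these two values lie within the scatter of each other, so compound 1 stands level with the only other measured compound. The next compound, compound 3 `Cc1ccc2[nH]c(-c3ccc(-c4ccc(-c5ccc(F)cc5)cc4)cc3)nc2c1`, keeps the core of compound 1 and changes a single group: fluoro in place of dimethylamino on an aromatic carbon, para to a large group (fluoro in place of dimethylamino on an aromatic carbon). Going by the values given here, only one measured step exists, a 1.4-fold higher number from compound 1 to compound 2 (0.13 log units; within the scatter), and it lies at a different place in the molecule. It therefore bears on this change only indirectly. Among the compounds with values here, no measured compound shows what happens when the dimethylamino group is altered, so the data give no direction for the change. The expectation therefore starts from compound 1 at 2210 nM in this assay. No step beyond the scatter is expected, and the estimate amounts to a 1.1-fold higher number from compound 1 to compound 3 (0.05 log units; within the scatter). On these data alone, the range is kept wide because this change is untested. For compound 3 the expected value is 2500 nM, with an estimated range of 600 nM to 10000 nM.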

Compound 3, concentration for 50% growth inhibition: 24600 nM
Estimate against measurement, compound 3: 9.8-fold (0.99 log units) below, and the stated range ends below it.
By their numbers in this assay, from the lowest: compounds 1 and 2 (each within the scatter of the next); then compound 3.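

In this assay, changing 4-(dimethylamino)phenyl to 4-fluorophenyl gives an 11-fold higher number from compound 1 to compound 3 (1.05 log units; beyond the scatter), so the group at this place, para to a large group, clearly affects growth inhibition. For the compounds shown here, the earlier pair differed at another place in the molecule and stayed within the scatter, whereas this single-group change on an otherwise unchanged core is the first step here to go beyond it. No measurement shown here explains why this exchange has so large an effect.

One pair cannot separate two readings: dimethylamino may help growth inhibition, or fluoro may harm it, and a simple amine, a methoxy group or a plain hydrogen at the same place would help tell these apart. On these data alone, it also remains open whether the same exchange would give a step of similar size in compound 2, which carries 4-hydroxy-1H-benzimidazol-2-yl in place of the 5-methyl-1H-benzimidazol-2-yl of compound 1.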